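Permeability of Three Measured Analogues and an Expected Fourth

The source may report more compounds than this note shows. Statements on the series, on what has been measured and on what is new or still open speak of the compounds shown alone.

Measured in an ADME assay for permeability, using PAMPA, with a stated time of 30 min, at pH 7.4 (on this read-out higher numbers stand for higher permeability and lower numbers for lower permeability), so far:
Compound 1, `FC(F)(F)c1ccc(-c2ccc3c(NCCCNCc4ccco4)ccnc3c2)cc1`, gives 237 10^-6 cm/s.
Compound 2, `CC(C)(C)c1ccc(-c2ccc3c(NCCCNCc4ccco4)ccnc3c2)cc1`, gives 237 10^-6 cm/s.
Compound 3, `COc1ccc(F)cc1CNCCCNc1ccnc2cc(-c3ccc(C(C)(C)C)cc3)ccc12`, gives 237 10^-6 cm/s.

Compound 1 differs from compound 2 by trifluoromethyl in place of tert-butyl on an aromatic carbon, and no change at the digits printed from compound 2 to compound 1 (within the scatter). The two cores differ in that compound 3 carries 5-fluoro-2-methoxyphenyl in place of furan-2-yl on a saturated chain carbon bound to an amine nitrogen, and no change at the digits printed from compound 2 to compound 3 (within the scatter). Compound 4, `COc1ccc(F)cc1CNCCCNc1ccnc2cc(-c3ccc(C(F)(F)F)cc3)ccc12`, is not yet measured in this assay. It differs from compound 3 by trifluoromethyl in place of tert-butyl on an aromatic carbon, the same change as from compound 2 to compound 1, at the same place. The expectation for compound 4 rests on that earlier step, no change at the digits printed from compound 2 to compound 1 (within the scatter), and on compound 1 and compound 2 being level with compound 3, which gives 237 10^-6 cm/s. Compound 4 is therefore expected to give 237 10^-6 cm/s, with a range from 120 10^-6 cm/s to 470 10^-6 cm/s. The expected step is no change at the digits printed from compound 3 to compound 4 (within the scatter).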

Compound 4, apparent permeability: 237 10^-6 cm/s
For compound 4 middle estimate and measured number coincide at the digits printed; the range from low to high includes it.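

In this assay, trifluoromethyl in place of tert-butyl gives no change at the digits printed from compound 3 to compound 4 (within the scatter), and this change reads the same on the two cores: the same change on two cores in this assay, no change at the digits printed (within the scatter) from compound 2 to compound 1 and no change at the digits printed (within the scatter) from compound 3 to compound 4, 1.0-fold (0.00 log units) apart, within the scatter of two such steps. Putting 5-fluoro-2-methoxyphenyl in place of furan-2-yl gives no change at the digits printed from compound 1 to compound 4 (within the scatter), and this change also carries over: the same change on two cores in this assay, no change at the digits printed (within the scatter) from compound 2 to compound 3 and no change at the digits printed (within the scatter) from compound 1 to compound 4, 1.0-fold (0.00 log units) apart, within the scatter of two such steps. Across these four compounds, both changes therefore carry from one core to the other without a step beyond the scatter, but this does not show that they would do so on another core, and the carrying over of a larger step remains untested.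

The compounds shown leave open how the read-out would respond to a nitrile or a carboxylic acid in place of trifluoromethyl. They also leave open the result of a longer chain in place of the present one.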